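Three measured analogues and an unmeasured thiophene analogue

The source may report more compounds than this note shows. Statements on the series, on what has been measured and on what is new or still open speak of the compounds shown alone.

In an assay on membranes from HeLa cells for displacement of a labelled ligand from adenosine receptor A3 (Homo sapiens), read by scintillation counting, with a stated time of 180 min, tested at 1 uM (a higher number here means more inhibition at the concentration tested (going by the name of the read-out), a lower number less inhibition), compound 1 `CCNC(=O)C1=C(C)NC(=O)NC1c1ccsc1` gives 1%. Going by the values given here, compound 2 `CCN(CC)C(=O)C1=C(C)NC(=O)NC1c1ccsc1` gives 35%; the one single-point step measured so far, a number 34 percentage points higher from compound 1 to compound 2 (beyond the scatter), is ethyl in place of hydrogen on an amide-type nitrogen. Compound 3 `CC1=C(C(=O)SC(C)C)C(c2ccco2)NC(=O)N1` gives 1%, level with compound 1 within the scatter, while compound 2 stands higher than both by a margin beyond the scatter.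

Compound 4 `CC1=C(C(=O)SC(C)C)C(c2ccsc2)NC(=O)N1` differs from compound 3 by thiophen-3-yl in place of furan-2-yl on a saturated ring carbon. Among the compounds with values here, no measured step exchanges one five-membered aromatic ring for another; the step from compound 1 to compound 2 sits on the amide-type nitrogen and does not bear on this change. With compound 3 at 1%, the expected step for compound 4 is a number 2 percentage points higher from compound 3 to compound 4 (within the scatter), nothing beyond the scatter. The estimate for compound 4 is 3%, between 0% and 15%.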

Compound 4, a percentage reported as inhibition, at one concentration (the size of the read-out at that concentration, not a potency): 1%
Estimate against measurement, compound 4: 2 percentage points above, within the range that was stated.
By their numbers in this assay, from the lowest: compounds 1, 3 and 4 (each within the scatter of the next); then compound 2.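

In this assay, the change on the saturated ring carbon gives no change at the digits printed from compound 3 to compound 4 (within the scatter), so with the (isopropylsulfanyl)carbonyl group in place, thiophen-3-yl and furan-2-yl cannot be told apart. On the carbonyl carbon, the read-out gives a number 34 percentage points lower from compound 2 to compound 4 (beyond the scatter) but no change at the digits printed from compound 1 to compound 4 (within the scatter), so isopropylsulfanyl stands apart from diethylamino and not from ethylamino. Nothing available explains these differences.

On these data alone, whether furan-2-yl and thiophen-3-yl also match when diethylamino sits on the carbonyl carbon remains open. So does the outcome for a cyclic amine such as piperidine, or for longer chains on the amide nitrogen.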